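The source may report more compounds than this note shows. Statements on the series, on what has been measured and on what is new or still open speak of the compounds shown alone.

Measured compounds:
compound 1, `NC1=NC2(CCOCC2)N(OCCCOc2cccc(Cl)c2)C(N)=N1` — in an assay on isolated protein for inhibition of Dihydrofolate reductase (Homo sapiens), read by spectrophotometry, using NADPH, with stated times of 5 s and 6 min (on this read-out lower numbers stand for stronger inhibition and higher numbers for weaker inhibition), compound 1 gives "not determined" (no result reported)
compound 2, `NC1=NC2(CCOCC2)N(OCCCOc2ccc(Cl)cc2)C(N)=N1` — in this assay compound 2 gives 33.6 nM
compound 3, `NC1=NC2(CCOCC2)N(OCCCOc2ccccc2Br)C(N)=N1` — in this assay compound 3 gives "not determined" (no result reported)

All three compounds share the same core and differ only in the group carried on an oxygen at the end of the short saturated chain. Only compound 2 has a number in this assay; compound 3 has no result there, and compound 1 likewise stands without a number, so nothing can be said about how compound 3 compares with the others.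

Compound 4, `NC1=NC2(CCOCC2)N(OCCCOc2ccc(Cl)cc2Cl)C(N)=N1`, is the next compound to be tested. It differs from compound 3 as follows: 2,4-dichlorophenyl in place of 2-bromophenyl on an oxygen on a saturated carbon. For the measured compounds named here, no step between measured compounds is available, so the only anchor is the single number given by compound 2, the one measured compound that also carries a chlorine-bearing ring on that oxygen.

On that basis the inhibitory concentration of compound 4 is expected to lie close to the value of compound 2, neither clearly stronger nor clearly weaker beyond the usual scatter. Compound 4 is estimated at 30 nM, within a range from 8 nM to 120 nM.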

Compound 4, half-maximal inhibitory concentration: 7.46 nM
For compound 4 the middle estimate is 4.0-fold (0.60 log units) above the measured one; the whole stated range lies above it.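

In this assay the ring on the oxygen now proves able to move the read-out: a chloro in place of hydrogen on an aromatic carbon gives a 4.5-fold lower number from compound 2 to compound 4 (0.65 log units; beyond the scatter), a modest change but one beyond the usual scatter. For the compounds shown here, this is the first comparison of two numbers, and it shows that this part of the molecule is not a silent passenger and that a ring with two chlorines is accepted, with stronger inhibition than the ring with one. The change from 2-bromophenyl to 2,4-dichlorophenyl cannot be read, with no number for compound 3, and nothing measured here explains the gain from the added chlorine.

On these data alone, what stays open is whether this gain belongs to chlorine itself or would also come with another group at the same place on the ring, such as a methyl, a methoxy or an amine. This single step also cannot say how a carboxylic acid on the ring, or a longer chain between the oxygen and the core, would change the number.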